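Aromatic substituents on a thiazolidine core and TSU-Pr1 growth inhibition

The compounds below may be only part of what the source reports. "The series", "measured", "known", "first", "only" and "open" are said of these compounds alone.

Compound 1 `CCCCCCCCCCCCCCCCCCNC(=O)[C@H]1CSC(C2CCCCC2)N1` carries a cyclohexyl group on the saturated ring carbon of its core. In a functional assay on TSU-Pr1 cells for antiproliferative activity against TSU (Homo sapiens), read by sulforhodamine B assay (on this read-out higher numbers stand for weaker inhibition and lower numbers for stronger inhibition), compound 1 gives only the assay limit of > 20000 nM (the limit of > 20000 nM in this assay, at which 1 of the 3 values shown sits). Compound 2 `CCCCCCCCCCCCCCCCCCNC(=O)[C@H]1CSC(c2c[nH]c3ccccc23)N1` gives 4400 nM and compound 3 `CCCCCCCCCCCCCCCCCCNC(=O)[C@H]1CSC(c2cccnc2)N1` gives 7800 nM; among the two numbers shown, compound 3 sits highest, with compound 2 nearest, a 1.8-fold higher number from compound 2 to compound 3 (0.25 log units; within the scatter). Both aromatic groups improved on the cyclohexyl: an at least 4.5-fold lower number from compound 1 to compound 2 (0.65 log units; beyond the scatter) and an at least 2.5-fold lower number from compound 1 to compound 3 (0.40 log units; beyond the scatter). Compound 4 `CCCCCCCCCCCCCCCCCCNC(=O)[C@H]1CSC(c2ccc(N(C)C)cc2)N1` differs from compound 3 by 4-(dimethylamino)phenyl in place of pyridin-3-yl on a saturated ring carbon. Since the swap between two aromatic groups in a 1.8-fold higher number from compound 2 to compound 3 (0.25 log units; within the scatter) stayed within the scatter, compound 4 is expected to show a step no larger than that, a 1.6-fold lower number from compound 3 to compound 4 (0.19 log units; within the scatter). Compound 4 is therefore estimated at 5000 nM, within 1500 nM to 15000 nM.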

Compound 4, half-maximal inhibitory concentration: 3000 nM
Estimate against measurement, compound 4: 1.7-fold (0.22 log units) above; low and high end bracket the measured number.
By their numbers in this assay, from the lowest: compounds 4, 2 and 3 (each within the scatter of the next, the first and the last beyond it). At a limit, above all of these: compound 1.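

In this assay, a 2.6-fold lower number from compound 3 to compound 4 (0.41 log units; beyond the scatter) shows that a swap between two aromatic groups on this saturated ring carbon can move the number beyond the scatter, which the step between compound 2 and compound 3 did not show. With a 1.5-fold lower number from compound 2 to compound 4 (0.17 log units; within the scatter) the 4-(dimethylamino)phenyl and 1H-indol-3-yl groups cannot be told apart. Against cyclohexyl the change gives an at least 6.6-fold lower number from compound 1 to compound 4 (0.82 log units; beyond the scatter) as a bound only, since compound 1 stands at a limit: the limit of > 20000 nM in this assay, at which 1 of the 4 values shown sits.

Going by these compounds, what an unsubstituted phenyl or a 4-carboxyphenyl would give on this carbon stays open, as does the effect of a shorter chain on the amide.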